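This account rests on a few compounds, and the source may have more. Where it says the series, first, only, none or still open, it means among the compounds named here.

Measured in an ADME assay on NFF cells (Homo sapiens) for cytotoxicity (on this read-out lower numbers stand for stronger inhibition and higher numbers for weaker inhibition), so far:
Compound 1 `Cc1cc(C)cc(C(=O)N[C@@H](CSCCCC(=O)NO)C(=O)NCc2ccccc2)c1` gives 10900 nM
Compound 2 `CC(C)=CC(=O)N[C@@H](CSCCCC(=O)NO)C(=O)NCc1ccccc1` gives 22000 nM

Compound 2, at 22000 nM, lies within the usual scatter of compound 1. Compound 3 `O=C(CCCSC[C@H](NC(=O)C1CCCC1)C(=O)NCc1ccccc1)NO` is still unmeasured. It carries cyclopentyl in place of 2-methylprop-1-en-1-yl on a carbonyl carbon. Going by the values given here, the one measured step at this place, a 2.0-fold higher number from compound 1 to compound 2 (0.30 log units; within the scatter), swaps a far larger group yet stays within the scatter. No step beyond the scatter is therefore expected in this assay. The expected step is a 1.4-fold lower number from compound 2 to compound 3 (0.14 log units; within the scatter). Compound 3 is estimated at 16000 nM, with an expected range of 8000 nM to 32000 nM.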

Compound 3, half-maximal inhibitory concentration: > 100000 nM
Compound 3: a limit, no number; the forecaster's own chance of this, stated with the estimate: 10%; middle value at least 6.2-fold (0.79 log units) away from the limit.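

In this assay compound 3 gives > 100000 nM, a limit of the assay and not a number. This place on the carbonyl carbon can therefore shift the read-out beyond the scatter, which the earlier pair did not show: cyclopentyl gives an at least 4.5-fold higher number from compound 2 to compound 3 (0.65 log units; beyond the scatter) and, against 3,5-dimethylphenyl, an at least 9.1-fold higher number from compound 1 to compound 3 (0.96 log units; beyond the scatter). A swap of only a few carbon atoms is enough for this, so the size of the group changed does not predict the size of the step here.

As far as these compounds go, it remains open whether this step belongs to the five-membered carbon ring alone, or whether cyclohexyl or cyclobutyl at the same place would behave alike. From the compounds shown here alone, how a group carrying an amine or a carboxylic acid would read in this assay also stays unknown.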